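A few compounds are considered here, and "the series" means these few. Any claim that something is new, unique, unknown or untested is made for them only; others in the source may bear on it.

In an assay (Equus caballus) for inhibition of Thromboxane-A synthase (Homo sapiens), using microsomes (a higher number here means a weaker inhibitor, a lower number a stronger inhibitor), compound 1 `CSC(CCC/C=C(\c1ccccc1)c1cccnc1)C(=O)O` gives 30 nM, the lowest of the three numbers in hand. Compound 3 `Cc1ccc(/C(=C/CCCCC(=O)O)c2cccnc2)cc1` gives 85 nM in this assay, and compound 2 `CCOC(=O)CCCC/C=C(\c1ccccc1)c1cccnc1` gives 600 nM. For the measured compounds named here, the only step between measured compounds that differ in one place runs from compound 1 to compound 2, where carboxy(methylsulfanyl)methyl is exchanged for ethoxycarbonyl methyl and the number rises by a 20-fold higher number from compound 1 to compound 2 (1.30 log units; beyond the scatter). Compound 4 `CC(C)CSC(CCC/C=C(\c1ccccc1)c1cccnc1)C(=O)O` differs from compound 1 in a smaller way: isopropyl in place of hydrogen on a saturated chain carbon bound to a sulfur, so that methylsulfanyl becomes isobutylsulfanyl while the carboxy group stays in place. That measured step removed the carboxy group and the sulfanyl group together, so it bears only loosely on a change that keeps the carboxy group and lengthens the sulfanyl substituent. Going by the values given here, no measured step alters the sulfanyl substituent alone. A shift in this assay beyond the scatter from compound 1 to compound 4 is therefore not expected, though a modest rise cannot be ruled out. Compound 4 is estimated at 40 nM, within 10 nM to 160 nM, a step of a 1.3-fold higher number from compound 1 to compound 4 (0.12 log units; within the scatter).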

Compound 4, half-maximal inhibitory concentration: 110 nM
Compound 4: the middle estimate sits 2.8-fold (0.44 log units) below what was measured, and the stated range covers the measured number.
By their numbers in this assay, from the lowest: compound 1; then compounds 3 and 4 (each within the scatter of the next); then compound 2.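

Enlarging the group on the sulfur while keeping the carboxy group, from methylsulfanyl to isobutylsulfanyl, gives a 3.7-fold higher number from compound 1 to compound 4 (0.56 log units; beyond the scatter) in this assay, so this position is not indifferent to the change. This step alters the sulfanyl substituent alone, and it is smaller than a 20-fold higher number from compound 1 to compound 2 (1.30 log units; beyond the scatter), where the carboxy group and the sulfanyl group were removed together. Nothing given here bears on why the number rises with isopropyl in place of hydrogen on this saturated chain carbon bound to a sulfur.

With a single larger group at this position, the compounds shown leave open whether the rise follows chain length or branching, which ethylsulfanyl or straight-chain butylsulfanyl would help separate. They also leave open how a phenyl ring or an amine on the sulfur substituent would read in this assay.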